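Fluorine pattern on the aryl of the three-membered ring

This account rests on a few compounds, and the source may have more. Where it says the series, first, only, none or still open, it means among the compounds named here.

Working notes on the series. Compound 1 `CC[C@H](C)[C@H](N)CN(C(=O)[C@@H]1C[C@H]1c1ccccc1)c1ccc(-c2ccccc2)cc1` carries a plain phenyl on the three-membered ring of the shared core; in a functional assay for agonist activity at G protein-coupled receptor 88 (Homo sapiens), read by HTRF and cAMP accumulation (on this read-out lower numbers stand for an effect already at smaller amounts and higher numbers for an effect only at larger amounts of compound), compound 1 gives 230 nM; 800 nM (2 entries), and the spread across its own repeats the several entries of compound 1 in this assay, 230 nM; 800 nM (2 entries) shows how far repeated numbers of this kind can fall apart. Compound 2 `CC[C@H](C)[C@H](N)CN(C(=O)[C@@H]1C[C@H]1c1cc(F)ccc1F)c1ccc(-c2ccccc2)cc1` carries a 2,5-difluorophenyl at that place; in this assay compound 2 gives 770 nM, the only number shown for it, one further entry having no single value. Compound 3 `CC[C@H](C)[C@H](N)CN(C(=O)[C@@H]1C[C@H]1c1ccc(F)cc1F)c1ccc(-c2ccccc2)cc1` has the same atoms joined differently: 2,4-difluorophenyl in place of 2,5-difluorophenyl on a saturated ring carbon. Going by the values given here, no measured pair shows this change, so the step of a 1.1-fold lower number from compound 2 to compound 3 (0.04 log units; within the scatter) is expected to stay within the usual scatter, with no direction favoured. Compound 3 is therefore estimated at 700 nM in this assay, with a range of 250 nM to 2000 nM.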

Compound 3, half-maximal effective concentration: 1300 nM
The estimate for compound 3 lay 1.9-fold (0.27 log units) below the measured number; the range from low to high includes it.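

With the same atoms joined differently, 2,4-difluorophenyl in place of 2,5-difluorophenyl on a saturated ring carbon gives, in this assay, a 1.7-fold higher number from compound 2 to compound 3 (0.23 log units; within the scatter). Going by these compounds alone, this is the first reading of a change in the fluorine pattern alone at this place, and it gives no sign that the assay separates these two patterns. A gap of this size is also no wider than what a single compound shows across its own repeats: the several entries of compound 1 in this assay, 230 nM; 800 nM (2 entries)

Still open, on these data alone, is how a methoxy group, a nitrile or an amine on this aryl would read in this assay, and whether a single fluorine would read apart from the two difluorophenyl patterns. The comparison here also rests on one number each for compound 2 and compound 3, so it says little about any finer preference between the two patterns.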